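The compounds below may be only part of what the source reports. "The series", "measured", "known", "first", "only" and "open" are said of these compounds alone.

Among the compounds with values here, compound 2 `CN(C)CCNc1ccnc2cc(F)ccc12` is one of two compounds measured in a functional assay on 184B5 cells (Homo sapiens) for cytotoxicity, read by sulforhodamine B assay, with a stated time of 48 h (a higher number here means a weaker inhibitor of growth, a lower number a stronger inhibitor of growth), where compound 2 gives 40400 nM. Its closest comparator is compound 1 `CN(C)CCNc1ccnc2cc(Cl)ccc12`, which in this assay gives 44500 nM. Within the data shown here, the single step between them, a 1.1-fold lower number from compound 1 to compound 2 (0.04 log units; within the scatter), amounts to a fluoro in place of chloro on an aromatic carbon, and on these two numbers compound 2 stands at the lower end, though not apart from compound 1 beyond the scatter.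

Compound 3 `COc1ccc2c(NCCN(C)C)ccnc2c1` differs from compound 2 by methoxy in place of fluoro on an aromatic carbon. Among the measured compounds shown here, the only measured step is the halogen exchange from compound 1 to compound 2, and it was within the scatter; no measured step covers the entry of a methoxy group. With that thin basis, no step beyond the scatter is expected, and compound 3 is estimated to give 40000 nM, in a range from 18000 nM to 90000 nM. That estimate corresponds to an expected step of a 1.0-fold lower number from compound 2 to compound 3 (0.00 log units; within the scatter).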

Compound 3, concentration for 50% growth inhibition: 44600 nM
Compound 3: the middle estimate sits 1.1-fold (0.05 log units) below what was measured, and the stated range covers the measured number.
By their numbers in this assay, from the lowest: compounds 2, 1 and 3 (each within the scatter of the next).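

In this assay, methoxy on this aromatic carbon gives a 1.1-fold higher number from compound 2 to compound 3 (0.04 log units; within the scatter) and a 1.0-fold higher number from compound 1 to compound 3 (0.00 log units; within the scatter), so neither replacement of a halogen moves the number beyond the scatter. The earlier pair had shown only one halogen exchanged for another, whereas this change brings in two heavy atoms, including an oxygen, and a hydrogen-bond acceptor, and the three compounds still cannot be separated. Nothing available explains why these three groups cannot be told apart here.

Going by these compounds, it remains open whether an amine, a carboxylic acid or a phenyl group on this aromatic carbon would give a step beyond the scatter. The compounds shown also leave open whether fluoro, chloro and methoxy would stay this close in other cells.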